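The source may hold more compounds than are shown below. What is called first, only, known or untested is meant among the compounds shown, and "the series" means these compounds.

Measured in a functional assay on Ishikawa cells (Homo sapiens) for antiproliferative activity, read by CCK-8 assay, with a stated time of 48 h; a lower number here means a stronger inhibitor, a higher number a weaker inhibitor:
- compound 1 `C=CC(=O)NCCOc1ccc(Oc2c(-c3ccc(F)cc3)sc3cc(O)ccc23)cc1`: > 25000 nM, a limit
- compound 2 `CN(C)C(=O)/C=C/CNCCOc1ccc(Oc2c(-c3ccc(F)cc3)sc3cc(O)ccc23)cc1`: 11900 nM
- compound 3 `O=C(CCCNCCOc1ccc(Oc2c(-c3ccc(F)cc3)sc3cc(O)ccc23)cc1)N1CCC1`: > 25000 nM, a limit

Compound 3 has no exact number, only a limit. That is the limit of > 25000 nM in this assay, at which 2 of the 3 values shown sit.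

The next compound is compound 4 `C=CC(=O)N1CC(Oc2ccc(Oc3c(-c4ccc(F)cc4)sc4cc(O)ccc34)cc2)C1`, and the change is 1-(vinylcarbonyl)azetidin-3-yl in place of 2-((3-((azetidin-1-yl)carbonyl)propyl)amino)ethyl on an oxygen on an aromatic ring. Compound 1 also carries vinylcarbonyl, and its result is likewise only a limit, > 25000 nM.

Among the compounds with values here, three measured steps bear on this change. The first is an at least 2.1-fold lower number from compound 1 to compound 2 (0.32 log units; beyond the scatter). The second is an at least 2.1-fold higher number from compound 2 to compound 3 (0.32 log units; beyond the scatter). The third is a step that the two limits leave unreadable from compound 1 to compound 3. Only compound 2, at 11900 nM, gives a real number, and compound 4 lacks its 3-(dimethylcarbamoyl)prop-2-en-1-yl group. A large gain in this assay is therefore not expected, and compound 4 may well reach the limit too.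

The expected change is an at least 1.2-fold lower number from compound 3 to compound 4 (0.09 log units; that floor lies within the scatter), a small one that the limit makes hard to read.

For compound 4 the estimate is 20000 nM, with an expected range of 8000 nM to 45000 nM.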

Compound 4, half-maximal inhibitory concentration: 12300 nM
Compound 4: the middle estimate sits 1.6-fold (0.21 log units) above what was measured; measured number inside the range.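

In this assay, 1-(vinylcarbonyl)azetidin-3-yl on the oxygen on the aromatic ring gives an at least 2.0-fold lower number from compound 3 to compound 4 (0.30 log units; that floor lies within the scatter) and an at least 2.0-fold lower number from compound 1 to compound 4 (0.30 log units; that floor lies within the scatter). Compound 1 carries vinylcarbonyl too, yet on its open chain it gives only a limit, so in these compounds vinylcarbonyl alone does not bring an exact number, while the same group on the azetidine ring of compound 4 does. Against the one other exact value, the result is a 1.0-fold higher number from compound 2 to compound 4 (0.01 log units; within the scatter), so the smaller azetidine group and the longer chain of compound 2 cannot be told apart, and the two earlier steps remain floors because compound 1 and compound 3 are limits: the limit of > 25000 nM in this assay, at which 2 of the 4 values shown sit.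

An azetidin-3-yl carrying a propanoyl group on its nitrogen would show whether the double bond of vinylcarbonyl counts here. A pyrrolidin-3-yl carrying vinylcarbonyl would show whether the four-membered ring counts.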